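Three substituents at one position of a shared core

The source may report more compounds than this note shows. Statements on the series, on what has been measured and on what is new or still open speak of the compounds shown alone.

Measured so far in a functional assay on KB cells (Homo sapiens) for cytotoxicity, read by spectrophotometry and crystal violet staining; a higher number here means a weaker inhibitor, a lower number a stronger inhibitor:
- compound 1, `N#Cc1c(Cl)n(C2O[C@H](CO)[C@@H](O)[C@H]2O)c2cc(Cl)c(Cl)cc12`: 65000 nM
- compound 2, `N/C(S)=N/N=C/c1c(Cl)n(C2O[C@H](CO)[C@@H](O)[C@H]2O)c2cc(Cl)c(Cl)cc12`: 65000 nM
- compound 3, `NC(=O)c1c(Cl)n(C2O[C@H](CO)[C@@H](O)[C@H]2O)c2cc(Cl)c(Cl)cc12`: 45000 nM

Compound 1 stands level with compound 2 at the digits printed, the two together giving the highest of the three numbers; its nearest neighbour is compound 2, with no change at the digits printed from compound 1 to compound 2 (within the scatter), and its furthest is compound 3, with a 1.4-fold lower number from compound 1 to compound 3 (0.16 log units; within the scatter). The three compounds differ only in the group on one aromatic carbon of the shared core, and compound 4, `COC(=N)c1c(Cl)n(C2O[C@H](CO)[C@@H](O)[C@H]2O)c2cc(Cl)c(Cl)cc12`, varies that same position once more: a group of 4 heavy atoms (2 carbon, 1 nitrogen, 1 oxygen; no ring) in place of a group of 2 heavy atoms (1 carbon, 1 nitrogen; no ring), on an aromatic carbon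

Going by the values given here, two measured steps bear on this change, both replacing the cyano group of compound 1 at that carbon: no change at the digits printed from compound 1 to compound 2 (within the scatter) and a 1.4-fold lower number from compound 1 to compound 3 (0.16 log units; within the scatter). Neither moved the number beyond the scatter, whether the entering group was large or small. The step to compound 4 is therefore expected to show no change beyond the scatter in this assay, a 1.2-fold lower number from compound 1 to compound 4 (0.07 log units; within the scatter) being the estimate. Compound 4 is estimated at 55000 nM, within a range from 25000 nM to 120000 nM.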

Compound 4, half-maximal inhibitory concentration: 50000 nM
Compound 4: middle estimate off by 1.1-fold (0.04 log units), on the high side, and the stated range covers the measured number.
By their numbers in this assay, from the lowest: compounds 3, 4, 1 and 2 (each within the scatter of the next).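

In this assay a group carrying a hydrogen-bond donor, which the cyano group lacks, leaves the number within the scatter against all three earlier compounds (a 1.3-fold lower number from compound 1 to compound 4 (0.11 log units; within the scatter); a 1.1-fold higher number from compound 3 to compound 4 (0.05 log units; within the scatter); a 1.3-fold lower number from compound 2 to compound 4 (0.11 log units; within the scatter)). No step among the four groups now tested on this aromatic carbon moves the number beyond the scatter, so this position has tolerated every change shown without any measurable separation between the compounds. Nothing available gives a reason for this lack of separation.

The compounds shown leave open whether any group on this carbon can move the number beyond the scatter, since none of the four has a ring and a carboxylic acid, an amine or a phenyl ring could behave differently. They also leave open whether replacing the chloro group at the neighbouring ring atom would change the number.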